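The source may hold more compounds than are shown below. What is called first, only, known or untested is meant among the compounds shown, and "the series" means these compounds.

Measured compounds:
- compound 1, `Cc1nc(C)n2c(Nc3cc[nH]n3)nccc12`: 53000 nM
- compound 2, `CCOC(=O)CSc1nncc2c(C)nc(C)n12`: a limit only, > 48000 nM
- compound 3, `CCOC(=O)CSc1nncc2c(C)ncn12`: a limit only, > 48000 nM

Within the data shown here, in a functional assay for inhibition, with Homo sapiens as the target (on this read-out higher numbers stand for weaker inhibition and lower numbers for stronger inhibition), compound 1 gives 53000 nM, the one plain number in the set. For compound 2 this assay reports only a limit, > 48000 nM. For compound 3 this assay likewise reports only a limit, > 48000 nM. The change from compound 3 to compound 2 is methyl in place of hydrogen on an aromatic carbon, and its step is a step that the two limits leave unreadable from compound 3 to compound 2; it cannot be read because of the limit of > 48000 nM in this assay, at which 2 of the 3 values shown sit.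

Compound 4, `Cc1cnc(Nc2cc[nH]n2)n2c(C)nc(C)c12`, carries the same kind of change relative to compound 1: methyl in place of hydrogen on an aromatic carbon. The place differs, though. In compound 2 the methyl sits on a five-membered aromatic ring with 2 nitrogen, between two ring nitrogen atoms, two ring bonds from the ring atom that bears a methyl group; in compound 4 it sits on a six-membered aromatic ring with 2 nitrogen, ortho to a fused ring, two atoms from the ring nitrogen, para to a (1H-pyrazol-3-yl)amino group. The difference between the two cores of compound 1 and compound 3 is not broken down here.

Among the measured compounds shown here, because the only measured step of this kind is a step that the two limits leave unreadable from compound 3 to compound 2, no direction is taken, and the expected step is a 1.2-fold lower number from compound 1 to compound 4 (0.07 log units; within the scatter). Compound 4 is estimated at 45000 nM, between 15000 nM and 150000 nM, and may well come back as a limit.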

Compound 4, half-maximal inhibitory concentration: > 48000 nM
Compound 4 gave a limit, no number; the forecaster's own chance of this, stated with the estimate: 40%; middle value at least 1.0-fold (0.02 log units) away from the limit.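

In this assay compound 4 gives only a limit, > 48000 nM. No step from compound 1 to compound 4 can be read, because the result stops at the limit: the limit of > 48000 nM in this assay, at which 3 of the 4 values shown sit.

The compounds shown leave open whether methyl in place of hydrogen on an aromatic carbon changes inhibition at all, in either core.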